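Halogen swap on an imide at the assay limit

The compounds below may be only part of what the source reports. "The series", "measured", "known", "first", "only" and "open" are said of these compounds alone.

Compound 1 `O=C(CCc1cc(Cl)ccc1NC(=O)c1ccccn1)c1ccccc1` gives 4500 nM in an assay on CHO cells for positive allosteric modulation of metabotropic glutamate receptor 5 (Homo sapiens), read by FLIPR; a higher number here means that more compound is needed for the effect, a lower number that less compound is needed. Compound 2 `Cc1ccc2c(c1C)C(=O)N(Cc1cc(Br)ccc1NC(=O)c1ccccn1)C2=O` in this assay reaches only the assay limit of > 100000 nM. That reading stands at the limit of > 100000 nM in this assay, at which 1 of the 2 values shown sits. Compound 3 `Cc1ccc2c(c1C)C(=O)N(Cc1cc(Cl)ccc1NC(=O)c1ccccn1)C2=O` carries chloro in place of bromo on an aromatic carbon. Among the measured compounds shown here, no measured pair in this set shows such a change, so the step from compound 2 to compound 3 in this assay is expected to stay within the usual scatter, with another limit the more likely outcome. Compound 3 is estimated at 150000 nM, within a range from 50000 nM to 500000 nM, which means an expected step that the limit leaves unreadable from compound 2 to compound 3.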

Compound 3, half-maximal effective concentration: 2200 nM
Compound 3: the middle estimate sits 68-fold (1.83 log units) above what was measured, and the stated range ends above it.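

In this assay, a single exchange of bromo for chloro on an aromatic carbon, para to the ((pyridin-2-yl)carbonyl)amino group, gives an at least 45-fold lower number from compound 2 to compound 3 (1.65 log units; beyond the scatter). On these data alone, the value of compound 2, > 100000 nM, is a limit of the assay and not a number, so the full size of this step stays unknown. This position is therefore sensitive to the identity of the halogen, at least on this imide.

The reason for the difference remains open, as this rests on one pair. Also open, as far as these compounds go, is how fluoro, methoxy or a plain hydrogen at this position would read.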